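The source may hold more compounds than are shown below. What is called first, only, known or untested is meant among the compounds shown, and "the series" means these compounds.

Compound 1 `O=C(O)C1CCN(c2nc(-c3cc(F)c(Cl)cc3F)nc3c2CS(=O)(=O)C3)CC1` gives > 3 mg/kg in a functional assay on the whole organism (blood, strain ICR) with Mus musculus as the target, in the glucose tolerance test, with a stated time of 30 min; a lower number here means that less compound is needed, a higher number that more compound is needed for the effect.
Compound 2 `O=S1(=O)Cc2nc(-c3cc(F)c(Cl)cc3F)nc(N3CCC(CCO)CC3)c2C1` gives 1 mg/kg in this assay.
Compound 3 `NC(=O)CCC1CCN(c2nc(-c3cc(F)c(Cl)cc3F)nc3c2CS(=O)(=O)C3)CC1` gives 0.3 mg/kg in this assay.

The value of compound 1 is only a limit of the test, not a measured number (the limit of > 3 mg/kg in this assay, at which 1 of the 3 values shown sits). Compound 2 carries 2-hydroxyethyl in place of carboxy on a saturated ring carbon, and the step from compound 1 to compound 2 in this assay is an at least 3.0-fold lower number from compound 1 to compound 2 (0.47 log units; beyond the scatter). Compound 3 carries 2-carbamoylethyl in place of carboxy on a saturated ring carbon, and the step in this assay is an at least 10-fold lower number from compound 1 to compound 3 (1.00 log units; beyond the scatter). Between the two, with carbamoyl in place of hydroxy on a saturated chain carbon, the step in this assay is a 3.3-fold lower number from compound 2 to compound 3 (0.52 log units; beyond the scatter).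

Compound 4 `CNC(=O)C1CCN(c2nc(-c3cc(F)c(Cl)cc3F)nc3c2CS(=O)(=O)C3)CC1` has not yet been measured. It differs from compound 1 as follows: methylamino in place of hydroxy on a carbonyl carbon. Both measured changes that replaced the carboxy group of compound 1 gave lower numbers in this assay, and the carbamoyl-bearing compound 3 gave the lowest of the three. Compound 4 is therefore expected to need a lower dose than compound 1, with an estimated step of an at least 6.0-fold lower number from compound 1 to compound 4 (0.77 log units; beyond the scatter). For compound 4 the estimate in this assay is 0.5 mg/kg, expected to lie between 0.1 mg/kg and 3 mg/kg.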

Compound 4, minimum effective dose: 3 mg/kg
The estimate for compound 4 lay 6.0-fold (0.78 log units) below the measured number; low and high end bracket the measured number.
By their numbers in this assay, from the lowest: compound 3; then compound 2; then compound 4.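

The carbonyl-linked amide does not by itself reproduce the low dose seen with the 2-carbamoylethyl group: in this assay, methylcarbamoyl in place of 2-carbamoylethyl on a saturated ring carbon gives a 10-fold higher number from compound 3 to compound 4 (1.00 log units; beyond the scatter). Compound 4 also falls behind the alcohol-bearing compound 2, with a 3.0-fold higher number from compound 2 to compound 4 (0.48 log units; beyond the scatter), so at this position both compounds with a two-carbon chain need less compound than the amide set directly on the ring. Compound 1 has only a limit of the test: the limit of > 3 mg/kg in this assay, at which 1 of the 4 values shown sits. The step that this limit allows is a number no higher from compound 1 to compound 4 (the limit leaves the size open), and its size cannot be read.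

On these data alone, these steps change the chain and the methyl on the amide nitrogen together, so the share of each stays open. A plain carbamoyl on the ring carbon, or a 2-(methylcarbamoyl)ethyl group, would separate the two.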